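Swapping Pyrazole for Methoxypyridine in a Receptor Binding Series

A few compounds are considered here, and "the series" means these few. Any claim that something is new, unique, unknown or untested is made for them only; others in the source may bear on it.

Compound 1 `O=C(O)Cc1sc(C(c2ccc(F)cc2)c2ccc(F)cc2)nc1-c1cccc(F)c1`, compound 2 `NS(=O)(=O)c1ccc(-c2nc(C(c3ccc(F)cc3)c3ccc(F)cc3)sc2CC(=O)O)cc1` and compound 3 `O=C(O)Cc1sc(C(c2ccc(F)cc2)c2ccc(F)cc2)nc1-c1cn[nH]c1` share one core and differ only in the aromatic group attached to it. In an in vitro assay on HEK385-7 cells for displacement of a labelled ligand from prostaglandin D2 receptor 2 (Homo sapiens) (on this read-out lower numbers stand for stronger inhibition and higher numbers for weaker inhibition), compound 1 gives 1.4 nM, compound 2 gives 1500 nM and compound 3 gives 16 nM. Compound 3 therefore stands second of the three measured numbers: its nearest neighbour is compound 1, separated by an 11-fold higher number from compound 1 to compound 3 (1.06 log units; beyond the scatter), and its furthest is compound 2, separated by a 94-fold lower number from compound 2 to compound 3 (1.97 log units; beyond the scatter).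

Compound 4 `COc1cc(-c2nc(C(c3ccc(F)cc3)c3ccc(F)cc3)sc2CC(=O)O)ccn1` has not yet been measured. Its change from compound 3 is 2-methoxypyridin-4-yl in place of 1H-pyrazol-4-yl on an aromatic carbon. Both measured steps exchange the group at the same position and both were large, but they point in opposite directions: the fluorinated six-membered ring of compound 1 sat well below compound 3, while the sulfamoyl-bearing six-membered ring of compound 2 sat far above it. A six-membered ring carrying a methoxy group and a ring nitrogen is expected to fall between those two outcomes, so the step of a 1.6-fold lower number from compound 3 to compound 4 (0.20 log units; within the scatter) is expected to stay modest, with a wide margin of uncertainty. Compound 4 is accordingly estimated at 10 nM, within a range from 2 nM to 60 nM.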

Compound 4, half-maximal inhibitory concentration: 29 nM
Compound 4: middle estimate off by 2.9-fold (0.46 log units), on the low side, and the stated range covers the measured number.
By their numbers in this assay, from the lowest: compound 1; then compounds 3 and 4 (each within the scatter of the next); then compound 2.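

In this assay, the exchange gives a 1.8-fold higher number from compound 3 to compound 4 (0.26 log units; within the scatter) and so leaves the number within the scatter, even though a five-membered aromatic ring with 1 hydrogen-bond donor gives way to a six-membered aromatic ring with 0 hydrogen-bond donors; every earlier step at this position had been large. The other two steps are a 21-fold higher number from compound 1 to compound 4 (1.32 log units; beyond the scatter) and a 52-fold lower number from compound 2 to compound 4 (1.71 log units; beyond the scatter) and both lie beyond the scatter, so compounds 1, 2 and 4, each with a six-membered aromatic ring at this position, show that ring size alone does not set the number. Nothing in the material at hand accounts for the size of any of these steps.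

The compounds shown leave open what the methoxy group and the ring nitrogen of the 2-methoxypyridin-4-yl group each contribute, and a pyridin-4-yl group without the methoxy group or a methoxyphenyl group would separate the two. Going by these compounds, it also remains open whether an amine or a hydroxyl group in place of the methoxy group would stay within the scatter of compound 4.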